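Shifting the Methoxy Group: From Compound 3 to Compound 4

The source may report more compounds than this note shows. Statements on the series, on what has been measured and on what is new or still open speak of the compounds shown alone.

Compound 3, `CCC1(CCCCN2CCN(c3cccc(OC)c3)CC2)C(=O)Nc2ccccc21`, was examined in a functional assay on the whole organism (strain Wistar) with Rattus norvegicus as the target, with a stated time of 5 min; on this read-out lower numbers stand for an effect already at smaller amounts and higher numbers for an effect only at larger amounts of compound. In this assay compound 3 gives only a limit, > 20 mg/kg, so no number stands behind it. Compound 1, `CCC1(CCCCN2CCN(c3ccc(OC)cc3)CC2)C(=O)Nc2ccccc21`, likewise gives a limit in this assay, > 20 mg/kg. Compound 2, `CCC1(CCCCN2CCN(c3cccc(Cl)c3)CC2)C(=O)Nc2ccccc21`, also gives a limit in this assay, > 20 mg/kg. Because all three values rest at the limit of > 20 mg/kg in this assay, at which 3 of the 3 values shown sit, the three steps among them cannot be read: a step that the two limits leave unreadable from compound 1 to compound 2, a step that the two limits leave unreadable from compound 1 to compound 3 and a step that the two limits leave unreadable from compound 2 to compound 3. Nothing in these three compounds therefore shows whether moving a substituent on the phenyl, or exchanging it, shifts the dose in either direction.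

Compound 4, `CCC1(CCCCN2CCN(c3ccccc3OC)CC2)C(=O)Nc2ccccc21`, differs from compound 3 by 2-methoxyphenyl in place of 3-methoxyphenyl on an amine nitrogen in a ring. Within the data shown here, no measured step bears readably on this change, so no direction beyond the scatter can be drawn from the data. The account expects compound 4 to behave like compound 3 and to stand at the limit as well, with an estimate of 30 mg/kg in this assay, spanning 8 mg/kg to 100 mg/kg. The expected step is therefore a step that the limit leaves unreadable from compound 3 to compound 4.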

Compound 4, minimum effective dose: 10 mg/kg
Beside the measured number, compound 4's estimate is 3.0-fold (0.48 log units) above it; measured number inside the range.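

In this assay compound 4 is the only one of the four compounds shown to give a number and not a limit, so 2-methoxyphenyl on the amine nitrogen in a ring is the one group here with a readable dose. Moving the methoxy group gives an at least 2.0-fold lower number from compound 3 to compound 4 (0.30 log units; that floor lies within the scatter), and the two exchanges on the same nitrogen give an at least 2.0-fold lower number from compound 2 to compound 4 (0.30 log units; that floor lies within the scatter) and an at least 2.0-fold lower number from compound 1 to compound 4 (0.30 log units; that floor lies within the scatter). The full size of these steps cannot be read because the other three compounds rest at a limit: the limit of > 20 mg/kg in this assay, at which 3 of the 4 values shown sit.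

The compounds shown leave open whether the dose follows the methoxy group itself or any group at this place on the phenyl, as 2-chlorophenyl or 2-ethoxyphenyl would test. They also leave open how plain phenyl on that nitrogen would read, or a longer chain leading to the shared core.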